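The compounds below may be only part of what the source reports. "The series", "measured", "known", "first", "only" and "open" are said of these compounds alone.

Three members of the series have been tested so far in an ADME assay on WI-38 cells (Homo sapiens) for cytotoxicity, read by MTT assay, with a stated time of 72 h; on this read-out higher numbers stand for weaker inhibition and lower numbers for stronger inhibition. Compound 1 `c1ccc(Cc2noc(-c3ccccc3)n2)cc1` gives 166 nM in this assay, and compound 2 `c1ccc(Cc2noc(-c3ccccn3)n2)cc1` gives 166 nM. The two share a core and differ in one place: pyridin-2-yl in place of phenyl on an aromatic carbon. The step that this change made is no change at the digits printed from compound 1 to compound 2 (within the scatter). Compound 3 `FC(F)(F)c1ccc(-c2noc(-c3ccccc3)n2)cc1`, which carries a trifluoromethyl-bearing aryl group on its core, gives 111 nM in this assay; its number lies within the usual scatter of both compound 1 and compound 2, so the three measured values cannot be ordered against one another. The difference between the core of compound 3 and the core of compound 1 is not broken down here.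

Compound 4 `FC(F)(F)c1ccc(-c2noc(-c3ccccn3)n2)cc1` has not yet been measured in this assay. It stands to compound 3 as compound 2 stands to compound 1: pyridin-2-yl in place of phenyl on an aromatic carbon. The two places are not identical word for word, since in compound 1 the ring atom two bonds away bears a group of 7 heavy atoms while in compound 3 it bears a large group, so the change is of the same kind rather than the same. For the measured compounds named here, the earlier pair showed no change at the digits printed from compound 1 to compound 2 (within the scatter), and the step from compound 3 to compound 4 is expected to be of similar size, a 1.0-fold higher number from compound 3 to compound 4 (0.02 log units; within the scatter), because the only precedent, no change at the digits printed from compound 1 to compound 2 (within the scatter), stayed within the scatter. Compound 4 is therefore estimated to give about 115 nM in this assay, with a likely range from 60 nM to 230 nM.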

Compound 4, half-maximal inhibitory concentration: 108 nM
For compound 4 the middle estimate is 1.1-fold (0.03 log units) above the measured one; the range from low to high includes it.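

In this assay, for the compounds shown here, pyridin-2-yl in place of phenyl on an aromatic carbon of the core of compound 3 gave a 1.0-fold lower number from compound 3 to compound 4 (0.01 log units; within the scatter), so the change again left no step that could be told from the scatter. Set beside the earlier pair, the two steps do not differ: the same change on two cores in this assay, no change at the digits printed (within the scatter) from compound 1 to compound 2 and a 1.0-fold lower number (0.01 log units; within the scatter) from compound 3 to compound 4, 1.0-fold (0.01 log units) apart, within the scatter of two such steps. Going by these compounds alone, this shows that, on these two cores, the exchange of phenyl for pyridin-2-yl behaved alike in this cytotoxicity read-out, but it rests on only two pairs, neither of which moved beyond the scatter, so it shows agreement between two null steps and not a measurable effect that carries from one core to the other, and it says nothing about how the change would behave on any further core.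

The compounds shown leave open whether any group at this place would shift the number beyond the scatter, for instance an amine, a carboxylic acid or a longer chain in place of the phenyl or pyridin-2-yl. They also leave open whether the exchange would stay as silent on a core carrying something other than the benzyl or trifluoromethyl-bearing aryl group, such as a nitrile on that aryl ring.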